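The compounds below may be only part of what the source reports. "The series", "measured", "known", "first", "only" and "open" are said of these compounds alone.

Compound 1, `O=C(/C=C/c1ccc(Cl)cc1)NS(=O)(=O)c1ccc(Cl)cc1`, in a functional assay on B16-F10 cells (Mus musculus) for antiproliferative activity, read by ELISA and MTT assay, with a stated time of 48 h (on this read-out lower numbers stand for stronger inhibition and higher numbers for weaker inhibition), gives 2.5 ug/mL.
Compound 2, `O=C(/C=C/c1ccc(Br)cc1)NS(=O)(=O)c1ccc(Cl)cc1`, in this assay gives 5.2 ug/mL.
Compound 3, `O=C(/C=C/c1ccccc1[N+](=O)[O-])NS(=O)(=O)c1ccc(Cl)cc1`, in this assay gives 6.6 ug/mL.

Compound 1 and compound 2 share a core and differ by bromo in place of chloro on an aromatic carbon, a change that brought a 2.1-fold higher number from compound 1 to compound 2 (0.32 log units; beyond the scatter). Compound 3 has a different core; the difference between the cores of compound 1 and compound 3 is not broken down here. The values of compound 3 and compound 2 lie within the usual scatter of each other.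

Compound 4, `O=C(/C=C/c1ccccc1[N+](=O)[O-])NS(=O)(=O)c1ccc(Br)cc1`, is not yet measured. It differs from compound 3 by bromo in place of chloro on an aromatic carbon, the same change, at the same place, as between compound 1 and compound 2. In this assay the step is expected to be of similar size to the earlier one, about a 1.7-fold higher number from compound 3 to compound 4 (0.22 log units; within the scatter), because the same change gave a 2.1-fold higher number from compound 1 to compound 2 (0.32 log units; beyond the scatter). Compound 4 is therefore estimated at 11 ug/mL, with a likely range from 5 ug/mL to 25 ug/mL.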

Compound 4, half-maximal inhibitory concentration: 12.6 ug/mL
Beside the measured number, compound 4's estimate is 1.1-fold (0.06 log units) below it, within the range that was stated.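

In this assay, putting bromo in place of chloro on the core of compound 3 gave a 1.9-fold higher number from compound 3 to compound 4 (0.28 log units; within the scatter). Set beside the earlier step, the change carried over from one core to the other at much the same size: the same change on two cores in this assay, a 2.1-fold higher number (0.32 log units; beyond the scatter) from compound 1 to compound 2 and a 1.9-fold higher number (0.28 log units; within the scatter) from compound 3 to compound 4, 1.1-fold (0.04 log units) apart, within the scatter of two such steps. Within the data shown here, these are only two pairs in one assay, so they do not show that the step would hold on a further core, and they do not explain why the number rises.

The compounds shown leave open how a fluoro group, a methoxy group, an amine or a carboxylic acid on that same aromatic carbon would compare with chloro and bromo.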